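Furan-3-yl in place of 6-fluoropyridin-3-yl on compound 2

A few compounds are considered here, and "the series" means these few. Any claim that something is new, unique, unknown or untested is made for them only; others in the source may bear on it.

compound 1 `N#Cc1ccc(N2CCc3cc(-c4cnc5ccccc5c4)ccc32)cc1C(F)(F)F`: "not determined" (no result reported)
compound 2 `CCN(c1ccc(C#N)c(Cl)c1)c1cc(-c2ccc(F)nc2)ccc1C`: 16500 nM
compound 3 `N#Cc1ccc(N2CCc3cc(-c4cccnc4)ccc3C2)cc1C(F)(F)F`: 4790 nM

In a functional assay on CWR22R cells (Homo sapiens) for antiproliferative activity, read by CCK-8 assay, with a stated time of 6 days (on this read-out higher numbers stand for weaker inhibition and lower numbers for stronger inhibition), compound 2 stands highest of the two numbers, and compound 3 lies below it, beyond the scatter. Compound 1 has no number. Compound 4 `CCN(c1ccc(C#N)c(Cl)c1)c1cc(-c2ccoc2)ccc1C` differs from compound 2 in one place: furan-3-yl in place of 6-fluoropyridin-3-yl on an aromatic carbon (furan-3-yl in place of 6-fluoropyridin-3-yl on an aromatic carbon, para to a methyl group). Among the measured compounds shown here, no measured pair shows this change, so the expectation rests on compound 2 alone (16500 nM). A small move toward stronger inhibition is expected, within the scatter. The expected change is a 1.7-fold lower number from compound 2 to compound 4 (0.22 log units; within the scatter) and is only a tentative estimate. Compound 4 is estimated at 10000 nM with an expected range from 3500 nM to 30000 nM once measured.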

Compound 4, half-maximal inhibitory concentration: > 30000 nM
Compound 4: a limit, no number; the forecaster's own chance of this, stated with the estimate: 10%; middle value at least 3.0-fold (0.47 log units) from the limit.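

In this assay compound 4 gives > 30000 nM, which is a limit of the assay and not a number. At this position, para to a methyl group, furan-3-yl in place of 6-fluoropyridin-3-yl gives an at least 1.8-fold higher number from compound 2 to compound 4 (0.25 log units; that floor lies within the scatter), so this five-membered ring brings no measurable gain in inhibition. How far the number rises cannot be read from the limit. The compounds shown leave open how this aromatic carbon would respond to a phenyl group or to an amine on the core of compound 2.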